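The source may hold more compounds than are shown below. What is called first, only, known or untested is meant among the compounds shown, and "the series" means these compounds.

Three compounds have been measured in a functional assay on MCF7 cells (Homo sapiens) for cytotoxicity, read by MTT assay, with a stated time of 3 days; on this read-out higher numbers stand for weaker inhibition and lower numbers for stronger inhibition:
compound 1, `COc1ccccc1-c1cccc(O)c1`, 44 ug/mL;
compound 2, `COc1ccc(-c2ccccc2)cc1`, > 100 ug/mL, which is a limit of the assay and not a number;
compound 3, `COc1ccc(-c2cccc(O)c2)c(OC)c1`, 50.2 ug/mL.

Compound 1 and compound 3 differ in one place only: methoxy in place of hydrogen on an aromatic carbon. This change gives a 1.1-fold higher number from compound 1 to compound 3 (0.06 log units; within the scatter), so the two compounds cannot be told apart on this read-out. Compound 2 stands on a different core, and the difference between its core and that of compound 1 is not broken down here. For compound 2 the assay reports no number at all, only (the limit of > 100 ug/mL in this assay, at which 1 of the 3 values shown sits).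

Compound 4, `COc1ccc(-c2ccccc2)cc1OC`, has not yet been measured. It differs from compound 2 by the same kind of change that separates compound 3 from compound 1: methoxy in place of hydrogen on an aromatic carbon. The surroundings are not the same word for word: in compound 3 the entering methoxy is meta to a methoxy group and para to a group of 7 heavy atoms, while in compound 4 it is ortho to a methoxy group and meta to a group of 6 heavy atoms.

Since the earlier change produced a 1.1-fold higher number from compound 1 to compound 3 (0.06 log units; within the scatter), a step of similarly small size is expected in this assay from compound 2 to compound 4, namely a step that the limit leaves unreadable from compound 2 to compound 4. Compound 4 is therefore estimated at about 150 ug/mL, expected to lie between 60 ug/mL and 400 ug/mL, with a real chance that the assay again returns only a limit.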

Compound 4, half-maximal inhibitory concentration: 45 ug/mL
Compound 4: middle estimate off by 3.3-fold (0.52 log units), on the high side; measured number below the stated range.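

In this assay compound 2 gives > 100 ug/mL, which is a limit of the assay and not a number. Measured against that limit, placing methoxy on an aromatic carbon of this core gives an at least 2.2-fold lower number from compound 2 to compound 4 (0.34 log units; beyond the scatter), a step that can be told from the scatter even though its full size stays hidden, and set beside the step on the other core it reads: the same change on two cores in this assay, a 1.1-fold higher number (0.06 log units; within the scatter) from compound 1 to compound 3 and an at least 2.2-fold lower number (0.34 log units; beyond the scatter) from compound 2 to compound 4; the limit leaves it open whether they differ. This shows that the change is not without a measurable step on every core in the series, but it does not show that the change acts differently on the two cores, nor that it acts alike, and with only two cases, in one of which the methoxy enters ortho to a methoxy group and meta to a group of 6 heavy atoms, no rule for carrying it across follows.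

The compounds shown leave open what number compound 2 would give and so how large the step on its core really is. They also leave open how other groups at the same place would read in this assay, such as an amine, a carboxylic acid or a longer chain in place of the methoxy.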